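A few compounds are considered here, and "the series" means these few. Any claim that something is new, unique, unknown or untested is made for them only; others in the source may bear on it.

Compound 1 `Cc1cc(Nc2cc(-c3ccccc3)[nH]n2)n2nc(SCCc3ccccc3)nc2n1`: 4930 nM in a functional assay on PC-9 cells (Homo sapiens) for inhibition, read by MTT assay, with a stated time of 72 h; a lower number here means a stronger inhibitor, a higher number a weaker inhibitor
Compound 2 `Cc1cc(Nc2cc(-c3ccccc3)[nH]n2)n2nc(SCc3cccc(Br)c3)nc2n1`: 8900 nM

Compound 1 stands at the lowest of the two numbers; its nearest neighbour is compound 2, reached by a 1.8-fold higher number from compound 1 to compound 2 (0.26 log units; within the scatter). Compound 3 `Cc1cc(Nc2cc(-c3ccccc3)[nH]n2)n2nc(SCc3cccc4ccccc34)nc2n1` differs from compound 1 by naphthalen-1-yl in place of benzyl on a saturated chain carbon bound to a sulfur. Among the measured compounds shown here, the only measured step at this position is the one from compound 1 to compound 2, which stayed within the scatter, so the exchange at the saturated chain carbon bound to a sulfur gives no grounds to expect a step beyond the scatter in this assay. Compound 3 is therefore estimated at 5500 nM, with a range of 2000 nM to 15000 nM, meaning an expected step of a 1.1-fold higher number from compound 1 to compound 3 (0.05 log units; within the scatter).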

Compound 3, half-maximal inhibitory concentration: 3950 nM
For compound 3 the middle estimate is 1.4-fold (0.14 log units) above the measured one; the measured number falls inside the stated range.
By their numbers in this assay, from the lowest: compounds 3, 1 and 2 (each within the scatter of the next, the first and the last beyond it).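

Replacing benzyl with naphthalen-1-yl at the saturated chain carbon bound to a sulfur gives a 1.2-fold lower number from compound 1 to compound 3 (0.10 log units; within the scatter) in this assay and so leaves the number close to that of compound 1. Among the compounds shown here, replacing 3-bromophenyl with naphthalen-1-yl at the same place gives a 2.3-fold lower number from compound 2 to compound 3 (0.35 log units; beyond the scatter) and is the first step here to pass beyond the scatter, although only modestly. From the compounds shown here alone, whether an amine, a carboxylic acid or a longer chain at this place would move the number further remains open. Nothing available explains these differences.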